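This account rests on a few compounds, and the source may have more. Where it says the series, first, only, none or still open, it means among the compounds named here.

Of the compounds shown here, three have been measured in a functional assay on RPMI18226 cells (Homo sapiens) for antiproliferative activity, read by sulforhodamine B assay, with a stated time of 48 h, tested at 10 uM; on this read-out lower numbers stand for less inhibition and higher numbers for more inhibition at the one concentration tested (going by the name of the read-out). Compound 1 `CN1C/C(=C\c2cccs2)C(=O)[C@@]2(C1)[C@H](c1cccs1)CN(C)[C@]21C(=O)N(C)c2ccccc21` gives 89.4% in this assay, and compound 2 `CN1C[C@@H](c2ccc(Cl)cc2)[C@@]2(Cc3ccccc3C2=O)[C@@]12C(=O)Nc1ccccc12` gives 63.4%. Compound 3 `O=C(Nc1ccccc1)c1c(-c2ccc(Cl)cc2)cc(-c2ccccc2)nc1N1CCCCC1` gives 13%, and this is the lowest of the three numbers: compound 2 stands a good way higher, further than the usual scatter of such a measurement, and compound 1 stands higher still, also well beyond the scatter. Compound 3 thus shows the lowest inhibition in this assay of the three.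

The next compound, compound 4 `O=C(Nc1ccccc1)c1c(-c2ccc(Cl)cc2)cc(-c2ccccc2)nc1Nc1ccc(Cl)cc1`, shares the core of compound 3 and differs from it in one place: (4-chlorophenyl)amino in place of piperidin-1-yl on an aromatic carbon. Within the data shown here, no step between two measured compounds of this kind is known, so the size of the change this brings in this assay cannot be read from the earlier numbers, and the three measured compounds give no pair that isolates this kind of swap.

With that in mind, the step from compound 3 to compound 4 is expected to be small, a number 9 percentage points higher from compound 3 to compound 4 (within the scatter), perhaps a modest rise but possibly nothing beyond the scatter. Compound 4 is therefore estimated to give about 22% in this assay, within a range from 2% to 48%.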

Compound 4, a percentage reported as inhibition, at one concentration (the size of the read-out at that concentration, not a potency): 53%
Compound 4: middle estimate off by 31 percentage points, on the low side, and the stated range ends below it.
By their numbers in this assay, from the lowest: compound 3; then compound 4; then compound 2; then compound 1.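

Among these compounds, the position on the aromatic carbon next to the ring nitrogen, ortho to the phenylcarbamoyl group, proves sensitive to what sits there: in this assay, putting (4-chlorophenyl)amino in place of piperidin-1-yl gives a number 40 percentage points higher from compound 3 to compound 4 (beyond the scatter), a large step and the first view of any change at this spot. This single swap alters several things at once: a six-membered non-aromatic ring leaves, a six-membered aromatic ring of carbon only enters along with a chlorine, and the entering group brings a hydrogen-bond donor that the leaving group lacks, so the step cannot be assigned to any one of these. Nothing available here points to a reason for the rise.

As far as these compounds go, a phenylamino group without the chlorine and a cyclohexylamino group at the same position would help separate the roles of the chlorine, the aromatic ring and the amino hydrogen, and how these groups would read remains open. Also open, from the compounds shown here alone, is how this step relates to potency, as each number here comes from a single concentration.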